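This account rests on a few compounds, and the source may have more. Where it says the series, first, only, none or still open, it means among the compounds named here.

Measured in a functional assay on DU-145 cells (Homo sapiens) for inhibition, read by trypan blue exclusion, with a stated time of 96 h; on this read-out higher numbers stand for weaker inhibition of growth and lower numbers for stronger inhibition of growth:

- compound 1 `CSc1ccc(/C=C(\C(=O)c2ccc(Br)cc2)S(=O)(=O)Cc2ccc(F)cc2)cc1` gives 50000 nM
- compound 2 `Cc1ccc(S(=O)(=O)/C(=C/c2sccc2C)C(=O)c2ccc(Br)cc2)cc1` gives 25000 nM
- compound 3 `Cc1ccc(S(=O)(=O)/C(=C/c2ccc(Br)cc2)C(=O)c2ccc(Br)cc2)cc1` gives 10000 nM

Compound 3 has the lowest number of the three, which means the strongest growth inhibition in this small set. Compound 4 `CSc1ccc(/C=C(\C(=O)c2ccc(Br)cc2)S(=O)(=O)c2ccc(C)cc2)cc1` changes it in one place, para to a large group on an aromatic carbon, with methylsulfanyl in place of bromo (methylsulfanyl in place of bromo on an aromatic carbon). Going by the values given here, one measured step concerns this same spot, a modest one (a 2.5-fold lower number from compound 2 to compound 3 (0.40 log units; beyond the scatter)) that brought in the 4-bromophenyl. Compound 1 also carries 4-(methylsulfanyl)phenyl and gives 50000 nM in this assay, but it differs elsewhere too. A modest move to a higher number is therefore expected (a 2.2-fold higher number from compound 3 to compound 4 (0.34 log units; beyond the scatter)). Compound 4 is estimated at 22000 nM (expected range 7000 nM to 60000 nM).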

Compound 4, concentration for 50% growth inhibition: 1000 nM
Beside the measured number, compound 4's estimate is 22-fold (1.34 log units) above it; measured number below the stated range.
By their numbers in this assay, from the lowest: compound 4; then compound 3; then compounds 2 and 1 (each within the scatter of the next).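

At this position, 4-(methylsulfanyl)phenyl gives stronger growth inhibition than either group seen before: methylsulfanyl in place of bromo gives a 10-fold lower number from compound 3 to compound 4 (1.00 log units; beyond the scatter) and 4-(methylsulfanyl)phenyl in place of 3-methylthiophen-2-yl gives a 25-fold lower number from compound 2 to compound 4 (1.40 log units; beyond the scatter) in the same direction. The group alone does not secure this, since compound 1 also carries it and 4-methylphenyl in place of 4-fluorobenzyl on the sulfonyl sulfur gives a 50-fold lower number from compound 1 to compound 4 (1.70 log units; beyond the scatter) as well. Nothing available explains these gains. From the compounds shown here alone, whether a methoxy group or an amine at this spot would match methylsulfanyl stays open, as does how the group behaves with other sulfonyl substituents.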